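The source may hold more compounds than are shown below. What is called first, only, known or untested is meant among the compounds shown, and "the series" means these compounds.

Measured so far in a functional assay on the whole organism (Tail, strain ICR) with Mus musculus as the target, in the tail flick test, with a stated time of 90 min, at a dose of 25 umol/kg by the oral route; a lower number here means a weaker effect, a higher number a stronger effect of the compound at the dose given:
compound 1 `CC[C@H](C)[C@H](NC(=O)CN(c1ncnc2c1ncn2C1CCCCO1)C1CC1)C(=O)OCc1ccccc1` – 22.6%
compound 2 `C[C@@H](O)[C@H](NC(=O)CN(c1ncnc2c1ncn2C1CCCCO1)C1CC1)C(=O)OCc1ccccc1` – 23.4%

Compound 2 sits at 23.4% in this assay, and compound 1 lies within the scatter of it: a number 0.8 percentage points higher from compound 1 to compound 2 (within the scatter). Neither of the two numbers can be set apart from the other.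

Compound 3 `NC(=O)C[C@H](NC(=O)CN(c1ncnc2c1ncn2C1CCCCO1)C1CC1)C(=O)OCc1ccccc1` is not yet measured. Its difference from compound 2 is carbamoylmethyl in place of 1-hydroxyethyl on a saturated chain carbon bound to an amide-type nitrogen and a carbonyl carbon. For the measured compounds named here, only one measured step touches the same part of the series, the exchange on the side chain of the benzyl ester from compound 1 to compound 2, and that step was within the scatter, a number 0.8 percentage points higher from compound 1 to compound 2 (within the scatter). Nothing measured speaks for a move beyond the scatter, so the expected step is small: a number 0.4 percentage points lower from compound 2 to compound 3 (within the scatter). Compound 3 is therefore estimated at 23% in this assay, with a range from 10% to 36%.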

Compound 3, a percentage reported as activity, at one dose (the size of the read-out at that dose, not a potency): 35%
The estimate for compound 3 lay 12 percentage points below the measured number; the range from low to high includes it.
By their numbers in this assay, from the lowest: compounds 1 and 2 (each within the scatter of the next); then compound 3.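

At the saturated chain carbon bound to an amide-type nitrogen and a carbonyl carbon, the group carried can change the read-out in this assay: carbamoylmethyl in place of 1-hydroxyethyl gives a number 11.6 percentage points higher from compound 2 to compound 3 (beyond the scatter), and carbamoylmethyl in place of sec-butyl gives a number 12.4 percentage points higher from compound 1 to compound 3 (beyond the scatter), both modest in size. For the compounds shown here, compound 1 and compound 2 could not be set apart, so carbamoylmethyl is the first group at this place to stand clear of the others. No available evidence bears on the reason for this difference.

It remains open whether the gain depends on the amide of carbamoylmethyl or on its chain, as the compounds shown include neither a carboxylic acid in place of that amide nor the longer carbamoylethyl chain. An amine on this same carbon chain also remains untested in the compounds shown.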